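Exchanging one group on a short-lived compound

The compounds below may be only part of what the source reports. "The series", "measured", "known", "first", "only" and "open" are said of these compounds alone.

Among the compounds with values here, in an ADME assay on microsomes from liver (Rattus norvegicus) for metabolic stability (on this read-out higher numbers stand for a longer-lived compound and lower numbers for a shorter-lived compound), compound 2 `CC(C)C(CC1NC(=O)NC1=O)c1ccc(-c2ccc3cccc(F)c3c2)[nH]c1=O` gives 0.35 h as the only true number so far. Compound 1 `C/C(=C1/OC(=O)NC1=O)C(c1ccc(-c2ccc3cccc(F)c3c2)[nH]c1=O)C(C)C` reads > 3 h in this assay and that is a limit of the assay, not a number.

Compound 3 `CC(C)C(/C=C1/C(=O)NC(=O)N1C)c1ccc(-c2ccc3cccc(F)c3c2)[nH]c1=O` is still unmeasured, and a group of 9 heavy atoms (5 carbon, 2 nitrogen, 2 oxygen; one five-membered non-aromatic ring with 2 hetero atoms) in place of a group of 8 heavy atoms (4 carbon, 2 nitrogen, 2 oxygen; one five-membered non-aromatic ring with 2 hetero atoms), on a saturated chain carbon bound to an aromatic carbon and a saturated chain carbon is what separates it from compound 2. The (2,5-dioxoimidazolidin-4-yl)methyl group leaves, and a new group enters on the same saturated chain carbon.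

Within the data shown here, one measured step bears on this change. an at least 8.5-fold lower number from compound 1 to compound 2 (0.93 log units; beyond the scatter) is also an exchange of a group at that place, and it is large and beyond the scatter. That single step shows that a swap here can move the half-life a long way, but it cannot tell which feature of the group matters. With compound 2 at 0.35 h a moderate rise therefore seems more likely than none. The expected move is a 2.9-fold higher number from compound 2 to compound 3 (0.46 log units; beyond the scatter) in this assay and it is only an estimate, with no change still possible. Compound 3 is expected at 1 h with an estimated range from 0.35 h to 3 h as its likely span.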

Compound 3, half-life: 1.08 h
Compound 3: middle estimate off by 1.1-fold (0.03 log units), on the low side, within the range that was stated.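

In this assay, the second exchange at this saturated chain carbon gives a 3.1-fold higher number from compound 2 to compound 3 (0.49 log units; beyond the scatter), so a modest gain in half-life is possible here with a group that keeps the five-membered non-aromatic ring with 2 hetero atoms. The step from the other side is an at least 2.7-fold lower number from compound 1 to compound 3 (0.44 log units; beyond the scatter), which places the new group apart from the group of compound 1 as well, and shows that groups of similar size at this place can give clearly different half-lives. Compound 1 reads > 3 h, a limit of the assay and not a number, so this step gives only the smallest possible size of the gap: the limit of > 3 h in this assay, at which 1 of the 3 values shown sits.

Within the data shown here, the entering group differs from the (2,5-dioxoimidazolidin-4-yl)methyl group in several ways at once, with 9 heavy atoms against 8, 3 double bonds outside aromatic rings against 2, and 1 hydrogen-bond donor against 2, and the single step cannot say which of these goes with the longer half-life. The compounds shown include no group that changes just one of these, such as the (2,5-dioxoimidazolidin-4-yl)methyl group with only a methyl added, and no open-chain group at this place, such as an amine or a carboxylic acid.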